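From a Long Ether Back to a Free Hydroxyl

The source may hold more compounds than are shown below. What is called first, only, known or untested is meant among the compounds shown, and "the series" means these compounds.

Compound 1, `CO[C@H]1CC=C2CCN(C)[C@H]2C1`: in an assay on HEK293 cells for displacement of a labelled ligand from Neuronal acetylcholine receptor; alpha3/beta4 (Rattus norvegicus), with a stated time of 4 h (on this read-out lower numbers stand for stronger inhibition and higher numbers for weaker inhibition), compound 1 gives 100000 nM.
Compound 2, `CCO[C@H]1CC=C2CCN(C)[C@H]2C1`: in this assay compound 2 gives > 300000 nM, which is a limit of the assay rather than a number.
Compound 3, `COCCO[C@H]1CC=C2CCN(C)[C@H]2C1`: in this assay compound 3 gives > 300000 nM, again a limit and not a number.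

The three measured compounds share one core and differ only in the group carried on its oxygen. For the measured compounds named here, compound 1 is the sole compound with a numerical value. Compound 3 sits at the limit of > 300000 nM in this assay, at which 2 of the 3 values shown sit, so its position is known only as a limit. Two steps can be read, both leading away from compound 1: an at least 3.0-fold higher number from compound 1 to compound 2 (0.47 log units; beyond the scatter) and an at least 3.0-fold higher number from compound 1 to compound 3 (0.47 log units; beyond the scatter). The remaining pair cannot be sized: a step that the two limits leave unreadable from compound 2 to compound 3.

Compound 4, `CN1CCC2=CC[C@H](O)C[C@@H]21`, is not yet measured. It differs from compound 3 by hydrogen in place of 2-methoxyethyl on an oxygen on a saturated carbon. This strips off the whole chain and goes one step smaller than compound 1, which keeps a methyl on that oxygen. Enlarging the ether beyond methyl gave weaker binding in both readable steps; shrinking it below methyl has no measured counterpart, so the expectation leans on compound 1 and its value 100000 nM. For compound 4 the expected step is an at least 3.0-fold lower number from compound 3 to compound 4 (0.47 log units; beyond the scatter). Compound 4 is therefore estimated at 100000 nM, within 20000 nM to 400000 nM.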

Compound 4, inhibition constant: > 300000 nM
Compound 4: no number, only a limit (the forecaster's own chance of this, stated with the estimate: 35%); middle value at least 3.0-fold (0.47 log units) away from the limit.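

Taking the methyl off the oxygen of compound 1 does not strengthen binding: in this assay, the free hydroxyl gives an at least 3.0-fold higher number from compound 1 to compound 4 (0.47 log units; beyond the scatter). Compound 4 gives > 300000 nM, which is a limit and not a number, so its steps to compound 2 and compound 3 cannot be read. Weaker binding now appears on both sides of the methyl ether, with a smaller group in compound 4 as well as larger ones in compound 2 and compound 3, and compound 1 alone keeps a number, while the rest of the series stops at one ceiling: the limit of > 300000 nM in this assay, at which 3 of the 4 values shown sit.

Going by these compounds, how far compound 2, compound 3 and compound 4 each lie past that limit remains unknown, and so does any order among them. Also open, on these data alone, is how an amine or a carboxylic acid would read at this place on the shared core, and whether any group there could give a clearly lower number than compound 1.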